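Moving the bromine on the amide-bound phenyl ring

This account rests on a few compounds, and the source may have more. Where it says the series, first, only, none or still open, it means among the compounds named here.

Compound 1 `N#Cc1ccc(NC(=O)c2csc(Cc3c(Cl)cccc3Cl)n2)cc1` carries a 4-cyanophenyl group on its amide nitrogen, and in an assay on CHO cells, read by calcium flux (a higher number here means a weaker inhibitor, a lower number a stronger inhibitor), compound 1 gives 720 nM. Compound 2 `O=C(Nc1ccccc1Br)c1csc(Cc2c(Cl)cccc2Cl)n1` carries a 2-bromophenyl group in the same place. In this assay compound 2 reaches only the limit > 4000 nM, so no exact number is known for it. The step of an at least 5.5-fold higher number from compound 1 to compound 2 (0.74 log units; beyond the scatter) therefore marks the 2-bromophenyl compound as the weaker of the two. Compound 3 `O=C(Nc1cccc(Br)c1)c1csc(Cc2c(Cl)cccc2Cl)n1` is the next compound: 3-bromophenyl in place of 2-bromophenyl on an amide-type nitrogen. Within the data shown here, no measured step compares a 2-bromophenyl with a 3-bromophenyl group, so the one step in hand, an at least 5.5-fold higher number from compound 1 to compound 2 (0.74 log units; beyond the scatter), bears on it only indirectly. That step ends at the limit of > 4000 nM in this assay, at which 1 of the 2 values shown sits, for compound 2, which leaves compound 3 room to read anywhere from somewhat stronger to equally weak. The step of a number no higher from compound 2 to compound 3 (the limit leaves the size open) is accordingly expected to be small, with no clear direction. Compound 3 is estimated at 4000 nM, within a range from 1000 nM to 15000 nM, and a fair chance remains that this assay again reports only a limit for it.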

Compound 3, half-maximal inhibitory concentration: > 4000 nM
Compound 3: a limit, no number; the forecaster's own chance of this, stated with the estimate: 55%; the middle value lies on the limit itself.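

Moving the bromine from the 2-bromophenyl to the 3-bromophenyl arrangement does not bring a readable value back in this assay: compound 3 gives > 4000 nM, which is a limit and not a number. Putting 3-bromophenyl in place of 4-cyanophenyl on the amide-type nitrogen gives an at least 5.5-fold higher number from compound 1 to compound 3 (0.74 log units; beyond the scatter), so the loss seen with the 2-bromophenyl group is not confined to that one arrangement of the bromine. The step between the two bromophenyl compounds cannot be read, and neither can be ranked over the other, as both stop at the same limit: the limit of > 4000 nM in this assay, at which 2 of the 3 values shown sit.

Going by these compounds, it remains open how weak the two bromophenyl compounds really are, and whether the loss comes with the bromine or with the absence of the nitrile. Also open, on these data alone, is how a phenyl ring carrying an amine or a carboxylic acid in place of the bromine would read on this amide-type nitrogen, and whether any such group would come close to compound 1.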